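The source may hold more compounds than are shown below. What is called first, only, known or untested is meant among the compounds shown, and "the series" means these compounds.

Measured in a functional assay on HeLa cells (Homo sapiens) for antiproliferative activity, read by MTT assay, with a stated time of 72 h; on this read-out higher numbers stand for weaker inhibition and lower numbers for stronger inhibition:
- Compound 1 `COc1cc(-c2ncnn2-c2cccc(N)c2)cc(OC)c1OC`: > 10000 nM (a limit)
- Compound 2 `COc1cc(-n2ncnc2-c2ccc(Cl)c(Cl)c2)cc(OC)c1OC`: > 10000 nM (a limit)
- Compound 3 `CCOc1cccc(-c2ncnn2-c2cc(OC)c(OC)c(OC)c2)c1`: > 10000 nM (a limit)

Compound 2 gives no number in this assay, only the limit > 10000 nM. The set as a whole offers no ranking, as the data show (the limit of > 10000 nM in this assay, at which 3 of the 3 values shown sit). Compound 4 `COc1cc(-n2ncnc2-c2ccc(SC)cc2)cc(OC)c1OC` carries 4-(methylsulfanyl)phenyl in place of 3,4-dichlorophenyl on an aromatic carbon. Within the data shown here, no measured step exists to guide the size of the change, so the expectation is loose: a shift towards stronger inhibition, perhaps a modest one, or none that the assay can resolve. The expected change is an at least 2.0-fold lower number from compound 2 to compound 4 (0.30 log units; that floor lies within the scatter). For compound 4 the estimated value is 5000 nM, with an expected range from 200 nM to 20000 nM.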

Compound 4, half-maximal inhibitory concentration: 150 nM
Compound 4: middle estimate off by 33-fold (1.52 log units), on the high side, and the stated range ends above it.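

In this assay, compound 4 is the only compound shown that gives a number rather than a limit, so the group on this aromatic carbon of the five-membered aromatic ring with 3 nitrogen can decide whether the series registers at all. Placing 4-(methylsulfanyl)phenyl there in place of 3,4-dichlorophenyl gives an at least 66-fold lower number from compound 2 to compound 4 (1.82 log units; beyond the scatter). That step has only a floor, since its starting point is a limit shared by most of the set: the limit of > 10000 nM in this assay, at which 3 of the 4 values shown sit.

Going by these compounds, its true size stays open. So does whether 4-(dimethylamino)phenyl or 4-ethylphenyl would do as well as 4-(methylsulfanyl)phenyl.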